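The compounds below may be only part of what the source reports. "The series", "measured", "known", "first", "only" and "open" are said of these compounds alone.

Compound 1 `CC(C)(C)c1cc(CNC(=O)Nc2cccc3[nH]ncc23)n(-c2cccc(Cl)c2)n1` in an assay on CHO-K1 cells for antagonist activity at transient receptor potential cation channel subfamily V member 1 (Homo sapiens), read by FLIPR and calcium flux, with a stated time of 6 min (a higher number here means a weaker inhibitor, a lower number a stronger inhibitor), gives 0.6 nM.
Compound 2 `O=C(NCc1cc(C(F)(F)F)nn1-c1cccc(C(F)(F)F)c1)Nc1cccc2[nH]ncc12` in this assay gives 1.3 nM.

Of the two measured compounds, compound 2 has the higher number and so is the weaker inhibitor, with compound 1 the nearest point and the gap between them beyond the usual scatter. Compound 3 `CC(C)c1ccc(-n2nc(C(F)(F)F)cc2CNC(=O)Nc2cccc3[nH]ncc23)cc1` differs from compound 2 in one place: 4-isopropylphenyl in place of 3-(trifluoromethyl)phenyl on an aromatic nitrogen. Going by the values given here, no measured pair shows this same change, so its effect is unknown; the expectation is a small step, a 1.5-fold higher number from compound 2 to compound 3 (0.19 log units; within the scatter), within or near the scatter, in either direction. Compound 3 is therefore expected to give 2 nM, with a range from 0.5 nM to 8 nM.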

Compound 3, inhibition constant: 4.1 nM
For compound 3 the middle estimate is 2.1-fold (0.31 log units) below the measured one; low and high end bracket the measured number.
By their numbers in this assay, from the lowest: compound 1; then compound 2; then compound 3.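

Putting 4-isopropylphenyl in place of 3-(trifluoromethyl)phenyl on the aromatic nitrogen gives, in this assay, a 3.2-fold higher number from compound 2 to compound 3 (0.50 log units; beyond the scatter). Going by these compounds alone, this is the first sign that the group on this nitrogen affects the inhibition constant, although compound 3 remains an inhibitor at 4.1 nM. Nothing available explains this modest loss.

The swap alters both the substituent and its place on the phenyl ring, and these two changes cannot be separated here. As far as these compounds go, a 4-(trifluoromethyl)phenyl group on this nitrogen would bear on that, and its effect remains open.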